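Substituent on the anilino ring: carboxy in place of hydrogen

A few compounds are considered here, and "the series" means these few. Any claim that something is new, unique, unknown or untested is made for them only; others in the source may bear on it.

Compound 1 `COc1ccc(S(=O)(=O)N2CCc3cccc(Nc4ccccc4)c32)cc1` is the parent of this pair; in a functional assay on MKN-45 cells (Homo sapiens) for antiproliferative activity (a lower number here means a stronger inhibitor, a higher number a weaker inhibitor), compound 1 gives 187 nM. For the measured compounds named here, its one measured neighbour, compound 2 `COc1ccc(S(=O)(=O)N2CCc3cccc(Nc4ccc([N+](=O)[O-])cc4)c32)cc1`, gives 107 nM in this assay. Among the two numbers recorded so far, compound 1 carries the higher one, with compound 2 nearest; the change between them, nitro in place of hydrogen on an aromatic carbon, produced a 1.7-fold lower number from compound 1 to compound 2 (0.24 log units; within the scatter), so the two sit within the same band.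

Compound 3 `COc1ccc(S(=O)(=O)N2CCc3cccc(Nc4ccc(C(=O)O)cc4)c32)cc1` has not yet been measured in this assay. Relative to compound 1 it differs by carboxy in place of hydrogen on an aromatic carbon. Going by the values given here, the only step that bears on this change is the one from compound 1 to compound 2, which put a nitro group on the same aromatic carbon and stayed inside the scatter at a 1.7-fold lower number from compound 1 to compound 2 (0.24 log units; within the scatter). On that single precedent, no step beyond the scatter is expected in either direction. Compound 3 is therefore estimated at 170 nM (range 70 nM to 400 nM) in this assay, which is expected to mean a 1.1-fold lower number from compound 1 to compound 3 (0.04 log units; within the scatter).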

Compound 3, half-maximal inhibitory concentration: 1390 nM
For compound 3 the middle estimate is 8.2-fold (0.91 log units) below the measured one; measured number outside the range, above it.
By their numbers in this assay, from the lowest: compounds 2 and 1 (each within the scatter of the next); then compound 3.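

In this assay this position on the anilino ring does not treat every substituent alike: carboxy in place of hydrogen gives a 7.4-fold higher number from compound 1 to compound 3 (0.87 log units; beyond the scatter) while nitro on the same aromatic carbon had stayed within the scatter of hydrogen. Exchanging one of these substituents for the other on that carbon gives a 13-fold higher number from compound 2 to compound 3 (1.11 log units; beyond the scatter) and this is the largest step in the set, so the outcome here depends on which group enters and not simply on hydrogen being replaced. No measurement at hand accounts for the higher number with carboxy, and its origin stays unassigned.

The compounds shown leave open whether the higher number belongs to the carboxylic acid specifically or would also appear with its methyl ester or a primary amide on the same carbon, and whether an amine there would fall with nitro or with carboxy. Also open, from the compounds shown here alone, is whether a longer chain ending in carboxy, set on that carbon, would give a step of similar size.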